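A bromo in place of methyl on compound 1

The source may hold more compounds than are shown below. What is called first, only, known or untested is meant among the compounds shown, and "the series" means these compounds.

Compound 1 `COc1cc(NCc2ccc(C)s2)ccc1-c1cnco1`: 24700 nM
Compound 2 `COc1ccc(-c2cnco2)cc1NCc1cccs1`: 53800 nM
Compound 3 `COc1cc(/N=C/c2ccncc2)ccc1-c1cnco1`: 239000 nM

All three compounds were tested in an ADME assay on Vero cells (Chlorocebus sabaeus) for cytotoxicity, read by MTT assay, with a stated time of 96 h; a higher number here means that more compound is tolerated, a lower number that less compound is tolerated. Compound 1 gives 24700 nM, the lowest of the three numbers. Its nearest neighbour, compound 2, gives 53800 nM, and the furthest, compound 3, gives 239000 nM. Both gaps from compound 1 lie beyond the usual scatter.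

The unmeasured compound 4 `COc1cc(NCc2ccc(Br)s2)ccc1-c1cnco1` keeps the core of compound 1 and differs from it in one place: bromo in place of methyl on an aromatic carbon. Put another way, 5-methylthiophen-2-yl becomes 5-bromothiophen-2-yl.

Among the measured compounds shown here, no two measured compounds show this exchange, or any other single change, so the data give no direct guide to its size or direction. The estimate therefore stays close to compound 1, with a wide range, and no change beyond the scatter is expected in this assay. The expected step is a 1.1-fold lower number from compound 1 to compound 4 (0.05 log units; within the scatter). For compound 4 the estimated value is 22000 nM, with an expected range from 9000 nM to 55000 nM.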

Compound 4, half-maximal cytotoxic concentration: 47300 nM
Estimate against measurement, compound 4: 2.2-fold (0.33 log units) below, and the stated range covers the measured number.
By their numbers in this assay, from the lowest: compounds 1, 4 and 2 (each within the scatter of the next, the first and the last beyond it); then compound 3.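

In this assay, bromo in place of methyl on an aromatic carbon next to the ring sulfur gives a 1.9-fold higher number from compound 1 to compound 4 (0.28 log units; within the scatter) and provides the first single-change step among these compounds. This position, two ring bonds from the ring atom that bears a large group, therefore takes either methyl or bromo without a change beyond the scatter, something that compounds 1, 2 and 3 could not show because none of them differs from another in one place alone. Nothing measured here accounts for the size of this step or for how it arises.

The compounds shown leave open how this same aromatic carbon would read with a different kind of group, such as an amine, a carboxylic acid or a longer chain like propyl, since methyl and bromo are the only two groups compared here. They also leave open whether the exchange of methyl for bromo would give a step of similar size and direction on a core other than that of compound 1.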